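Lengthening the Amine Chain on a Shared Core

The compounds below may be only part of what the source reports. "The series", "measured", "known", "first", "only" and "open" are said of these compounds alone.

Of the compounds shown here, three built on one shared core have so far been measured in an assay on urine for inhibition of Myeloperoxidase (Homo sapiens); on this read-out lower numbers stand for stronger inhibition and higher numbers for weaker inhibition. Compound 1 `CN1CCN(Cc2c[nH]c3ccc(F)cc23)CC1` gives 1000 nM. Compound 2 `CNCCCc1c[nH]c2ccc(F)cc12` gives 200 nM. Compound 3 `CN1CCN(CCCc2c[nH]c3ccc(F)cc23)CC1` gives 350 nM. Compound 2 thus has the lowest number of the three; its gap to compound 3 falls within the usual scatter, so those two cannot be told apart, while its gap to compound 1 lies beyond the scatter.

The next compound, compound 4 `NCCCCCCc1c[nH]c2ccc(F)cc12`, has not yet been measured in this assay. It differs from compound 2 in one place: 3-aminopropyl in place of methylamino on a saturated chain carbon, three bonds along the chain from an aromatic carbon. In plain words, the short methylamino tail is traded for a longer 3-aminopropyl tail, so the nitrogen sits further out along the chain and no longer carries a methyl.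

Among the measured compounds shown here, no measured pair in this set isolates that change, so there is no step to lean on. Judged only from the three numbers, a modest shift in either direction seems possible, and nothing demands a move beyond the scatter. The step from compound 2 to compound 4 is expected to be a 1.5-fold higher number from compound 2 to compound 4 (0.18 log units; within the scatter). Compound 4 is therefore estimated at 300 nM, with a plausible range from 100 nM to 1000 nM.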

Compound 4, half-maximal inhibitory concentration: 260 nM
Estimate against measurement, compound 4: 1.2-fold (0.06 log units) above, and the stated range covers the measured number.
By their numbers in this assay, from the lowest: compounds 2, 4 and 3 (each within the scatter of the next); then compound 1.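

In this assay the trade of methylamino for 3-aminopropyl, on a saturated chain carbon three bonds along the chain from an aromatic carbon, gives a 1.3-fold higher number from compound 2 to compound 4 (0.11 log units; within the scatter) and so the two compounds cannot be told apart. Among the compounds shown here, this is the first direct reading at this position, and it shows that the chain end can be made longer, with its nitrogen no longer carrying a methyl, without any change that stands out from the usual spread of repeat measurements. No measurement on hand gives a reason why these two tails read alike.

The step also joins two changes, the longer tail and the loss of the methyl, so a methylamino group at the end of the longer chain would be needed to separate them. On these data alone, how much the amine itself matters, and how far the tail can grow, remain open, and a hydroxyl group or a carboxylic acid in place of the terminal amine, or a still longer chain, would bear on those questions.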